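Swapping the aryl group and watching cell toxicity

This account rests on a few compounds, and the source may have more. Where it says the series, first, only, none or still open, it means among the compounds named here.

This piece concerns two compounds whose toxicity toward a human cell line has been measured, and a third for which the result is still awaited. The read-out is an ADME assay on MT4 cells (Homo sapiens) for cytotoxicity, read by MTT assay, with a stated time of 4 days; on this read-out higher numbers stand for lower toxicity in this test and lower numbers for higher toxicity in this test. Compound 1 is `Cc1cc(-c2cccc(C(F)(F)F)c2)cc(C)c1Nc1ccnc(Nc2ccc(C#N)cc2)n1`, and in this assay compound 1 gives 4030 nM. Compound 2 is `COc1ccccc1-c1cc(C)c(Nc2ccnc(Nc3ccc(C#N)cc3)n2)c(C)c1`, and in this assay compound 2 gives 940 nM. Compound 1 therefore stands at the top of the two numbers on hand, meaning it is the less toxic of the pair. Among the compounds with values here, the one change between them gave a 4.3-fold lower number from compound 1 to compound 2 (0.63 log units; beyond the scatter).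

Compound 3 is `Cc1cc(-c2ccccc2Cl)cc(C)c1Nc1ccnc(Nc2ccc(C#N)cc2)n1`. It differs from compound 1 in a single place: 2-chlorophenyl in place of 3-(trifluoromethyl)phenyl on an aromatic carbon. Within the data shown here, the only measured step that bears on this is the one from compound 1 to compound 2, where the same group left and a different one entered, and the number fell well beyond the scatter. A similar, though possibly smaller, fall is expected here. Compound 3 is estimated to give 1800 nM, within a range of 700 nM to 4500 nM, which would mean an expected step of a 2.2-fold lower number from compound 1 to compound 3 (0.35 log units; beyond the scatter).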

Compound 3, half-maximal cytotoxic concentration: 3990 nM
Compound 3: the middle estimate sits 2.2-fold (0.35 log units) below what was measured; low and high end bracket the measured number.
By their numbers in this assay, from the lowest: compound 2; then compounds 3 and 1 (each within the scatter of the next).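

In this assay, 2-chlorophenyl in place of 3-(trifluoromethyl)phenyl gave a 1.0-fold lower number from compound 1 to compound 3 (0.00 log units; within the scatter), so this position accepts two quite different aryl groups with no visible shift in the read-out, and losing 3-(trifluoromethyl)phenyl does not by itself lower the number. The step with chloro in place of methoxy gave a 4.2-fold higher number from compound 2 to compound 3 (0.63 log units; beyond the scatter), which shows that the lower number of compound 2 goes with its 2-methoxyphenyl group and not with simply replacing 3-(trifluoromethyl)phenyl; among these three compounds, compound 2 alone stands apart. Nothing on hand explains why the methoxy compound differs from the other two.

From the compounds shown here alone, with a single methoxy example, it remains open whether the lower number follows methoxy wherever it sits on this phenyl ring, or whether a related group such as hydroxy or ethoxy would behave the same way. It is also open how this read-out would respond to a phenyl ring carrying an amine or a carboxylic acid, since every aryl group shown here has only a methoxy, chloro or trifluoromethyl substituent.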